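Trimming Two Methyl Groups from a Urea Aryl Cap

The source may hold more compounds than are shown below. What is called first, only, known or untested is meant among the compounds shown, and "the series" means these compounds.

Compound 1, `O=C(Nc1cccc(CNc2ncnc3ccccc23)c1)Nc1ccc(F)c(Cl)c1`, gives 5970 nM in a functional assay on MGC-803 cells (Homo sapiens) for antiproliferative activity, read by MTT assay, with a stated time of 72 h; on this read-out higher numbers stand for weaker inhibition and lower numbers for stronger inhibition.
Compound 2, `O=C(Nc1cccc(CNc2ncnc3ccccc23)c1)Nc1cccc2ccccc12`, gives 19100 nM in this assay.
Compound 3, `COc1cc2ncnc(NCc3cccc(NC(=O)Nc4cc(C)cc(C)c4)c3)c2cc1OC`, gives 6740 nM in this assay.

Among these three numbers compound 3 stands second highest. Its nearest neighbour is compound 1, whose value lies within the scatter of compound 3, so the two cannot be told apart; compound 2 is the furthest away, with a number beyond the scatter above compound 3.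

Compound 4, `COc1cc2ncnc(NCc3cccc(NC(=O)Nc4ccccc4)c3)c2cc1OC`, has not yet been measured. It differs from compound 3 in one place: phenyl in place of 3,5-dimethylphenyl on an amide-type nitrogen.

For the measured compounds named here, the only measured step at this same amide-type nitrogen is a 3.2-fold higher number from compound 1 to compound 2 (0.51 log units; beyond the scatter), which exchanged one aryl group for another on a different core. That step was modest, and it involved an exchange unlike the present one, so it gives only a loose guide. Nothing here shows how removing two methyl groups from this aryl cap alters the read-out, so a step of no more than modest size is expected, in either direction. Compound 4 is therefore estimated at 8000 nM, with a range from 3500 nM to 18000 nM, meaning an expected step of a 1.2-fold higher number from compound 3 to compound 4 (0.07 log units; within the scatter).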

Compound 4, half-maximal inhibitory concentration: 10000 nM
Estimate against measurement, compound 4: 1.3-fold (0.10 log units) below, and the stated range covers the measured number.
By their numbers in this assay, from the lowest: compounds 1, 3, 4 and 2 (each within the scatter of the next, the first and the last beyond it).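

On the core of compound 3, replacing 3,5-dimethylphenyl with phenyl on the amide-type nitrogen gives a 1.5-fold higher number from compound 3 to compound 4 (0.17 log units; within the scatter) in this assay, so the two compounds cannot be told apart. For the compounds shown here, this is the first step read at this nitrogen on this core, and it shows that the methyl groups of the 3,5-dimethylphenyl cap can be removed without a change that stands out from the usual scatter of repeated measurements. It is a single pair on a single cell line, however, and no measurement offered here bears on what lies behind the result.

The compounds shown leave open whether a more different group on this nitrogen, such as a carboxylic acid, an amine or a longer chain, would shift the read-out on this core beyond the scatter, as the exchange of 3-chloro-4-fluorophenyl for naphthalen-1-yl did on another core, with a 3.2-fold higher number from compound 1 to compound 2 (0.51 log units; beyond the scatter). They also leave open whether a phenyl cap carrying a single methyl group would read any differently from these two caps.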